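A few compounds are considered here, and "the series" means these few. Any claim that something is new, unique, unknown or untested is made for them only; others in the source may bear on it.

Compound 1 `O=C(CN1C(=O)S/C(=C/c2ccco2)C1=O)Nc1ccc(Cl)c(Cl)c1`: 72200 nM
Compound 2 `O=C(CN1C(=O)S/C(=C/c2ccco2)C1=O)Nc1ccc(Br)cc1`: 98200 nM
Compound 3 `O=C(CN1C(=O)S/C(=C/c2ccco2)C1=O)Nc1nc2ccccc2s1`: 15300 nM

In a functional assay on KCL-22 cells (Homo sapiens) for cytotoxicity, read by propidium iodide staining, with a stated time of 48 h (on this read-out higher numbers stand for lower toxicity in this test and lower numbers for higher toxicity in this test), compound 3 gives 15300 nM, the lowest number of the three and clearly apart from the other two. Compound 4 `Cc1cccc2sc(NC(=O)CN3C(=O)S/C(=C/c4ccco4)C3=O)nc12` keeps all of compound 3 except for one change: methyl in place of hydrogen on an aromatic carbon. For the measured compounds named here, only one measured step changes a single place, a 1.4-fold higher number from compound 1 to compound 2 (0.13 log units; within the scatter). It exchanges one group on the amide nitrogen for another and stays small, but it says little about this change. Going by the values given here, no measured step adds a methyl, so there is no evidence for a real shift in either direction. The expected result is a 1.0-fold lower number from compound 3 to compound 4 (0.01 log units; within the scatter), which would be no change beyond the scatter. For compound 4 the estimated value is 15000 nM, with an expected range of 6500 nM to 36000 nM.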

Compound 4, half-maximal cytotoxic concentration: 97000 nM
Beside the measured number, compound 4's estimate is 6.5-fold (0.81 log units) below it; the measured number lies above the stated range.
By their numbers in this assay, from the lowest: compound 3; then compounds 1, 4 and 2 (each within the scatter of the next).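

In this assay a single methyl in place of hydrogen on this aromatic carbon gives a clear shift (a 6.3-fold higher number from compound 3 to compound 4 (0.80 log units; beyond the scatter)), so this position is not indifferent to even a small addition. The earlier compounds shown here differ at the amide nitrogen, so they could not show this. Nothing available explains why the number moves toward lower toxicity in this test. The compounds shown leave open whether this shift is particular to methyl or would appear with other groups. A methoxy group or a chlorine atom on the same carbon would help separate these possibilities.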